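A few compounds are considered here, and "the series" means these few. Any claim that something is new, unique, unknown or untested is made for them only; others in the source may bear on it.

Compound 3 `N#Cc1c(-c2ccccc2)cn(-c2ccc(S(=O)(=O)Nc3ccccn3)cc2)c1NC(=O)CCC(=O)O` gives 3750 nM in a functional assay on HepG2 cells (Homo sapiens) for inhibition, read by sulforhodamine B assay, with a stated time of 24 h; a lower number here means a stronger inhibitor, a higher number a weaker inhibitor. Compound 2 `N#Cc1c(-c2ccccc2)cn(-c2ccc(S(=O)(=O)Nc3nccs3)cc2)c1NC(=O)CCC(=O)O` gives 3750 nM in this assay, and compound 1 `CC(=O)Nc1c(C#N)c(-c2ccccc2)cn1-c1ccc(S(=O)(=O)Nc2ccccn2)cc1` gives 3490 nM in this assay; the three numbers lie within the scatter of one another, so none of them can be set apart from the others. The step of a 1.1-fold higher number from compound 1 to compound 3 (0.03 log units; within the scatter) and the step of no change at the digits printed from compound 2 to compound 3 (within the scatter) both left the number essentially where it was.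

Compound 4 `N#Cc1c(-c2ccccc2)cn(-c2ccc(S(=O)(=O)Nc3ccccn3)cc2)c1N1C(=O)CCC1=O` differs from compound 3 by 2,5-dioxopyrrolidin-1-yl in place of ((2-carboxyethyl)carbonyl)amino on an aromatic carbon. Neither measured step touches this kind of change: one added the carboxymethyl to the chain, the other swapped the group on the sulfonamide nitrogen, and both stayed within the scatter. The ring closure itself is untested among these compounds. Compound 4 is therefore expected to give a number close to that of compound 3. The step of a 1.1-fold lower number from compound 3 to compound 4 (0.03 log units; within the scatter) is expected to stay within the scatter. The estimate for compound 4 in this assay is 3500 nM, within a range from 1500 nM to 8500 nM.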

Compound 4, half-maximal inhibitory concentration: 5360 nM
Beside the measured number, compound 4's estimate is 1.5-fold (0.19 log units) below it; measured number inside the range.
By their numbers in this assay, from the lowest: compounds 1, 2, 3 and 4 (each within the scatter of the next).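

In this assay, 2,5-dioxopyrrolidin-1-yl in place of the open ((2-carboxyethyl)carbonyl)amino chain gives a 1.4-fold higher number from compound 3 to compound 4 (0.16 log units; within the scatter) and, in place of acetamido, gives a 1.5-fold higher number from compound 1 to compound 4 (0.19 log units; within the scatter) on the same aromatic carbon. This position therefore carries an open chain ending in a carboxylic acid, a short acetamido group and a closed five-membered ring without the number leaving the scatter, even though the entering ring has no hydrogen-bond donor and the chain it replaces does. Nothing available gives a reason for these numbers.

The compounds shown leave open whether a free amine or a longer chain on this carbon would move the number beyond the scatter. They also leave open whether the closed ring behaves the same with 1,3-thiazol-2-yl on the sulfonamide nitrogen.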